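Swapping a bromophenyl for a dimethylphenyl: cytotoxicity outlook

The compounds below may be only part of what the source reports. "The series", "measured", "known", "first", "only" and "open" are said of these compounds alone.

Measured so far:
- Compound 1, `Cc1c(Cc2ccccc2Br)nc(SCc2ccc([N+](=O)[O-])cc2)[nH]c1=O`, gives >= 246000 nM in an ADME assay on MT4 cells (Homo sapiens) for cytotoxicity, read by MTT assay; a lower number here means that less compound is tolerated, a higher number that more compound is tolerated.
- Compound 2, `COc1ccc(CSc2nc(Cc3ccc(Br)cc3)c(C)c(=O)[nH]2)cc1`, gives > 290000 nM in this assay.
- Compound 3, `COc1ccc(CSc2nc(Cc3ccc(-c4ccccc4)cc3)c(C)c(=O)[nH]2)cc1`, gives 100000 nM in this assay.

For compound 1 the result is a limit of the assay and not a number, sitting at the limit of >= 246000 nM in this assay, at which 1 of the 3 values shown sits. Compound 2 likewise sits at a limit, (the limit of > 290000 nM in this assay, at which 1 of the 3 values shown sits). Among the compounds with values here, only compound 3 returns a number, and the one step between measured compounds, an at least 2.9-fold lower number from compound 2 to compound 3 (0.46 log units; beyond the scatter), went in the direction of less compound being tolerated.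

Compound 4, `Cc1cc(C)cc(Cc2nc(SCc3ccc([N+](=O)[O-])cc3)[nH]c(=O)c2C)c1`, differs from compound 1 by 3,5-dimethylphenyl in place of 2-bromophenyl on a saturated chain carbon bound to an aromatic carbon. Within the data shown here, no measured step matches this change: the step from compound 2 to compound 3 changed a group on the ring itself, not the ring. Compound 4 is therefore expected to remain close to compound 1, with a step of an at least 1.3-fold lower number from compound 1 to compound 4 (0.13 log units; that floor lies within the scatter) that may well fall within the scatter. The estimate for compound 4 in this assay is 180000 nM, between 70000 nM and 300000 nM, with a fair chance that only a limit is reported.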

Compound 4, half-maximal cytotoxic concentration: > 316000 nM
Compound 4: no number, only a limit; the forecaster's own chance of this, stated with the estimate: 50%; middle value at least 1.7-fold (0.24 log units) away from the limit.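

Compound 1 and compound 4 both return only limits of the assay, not numbers, in this assay, and the step between them cannot be read. The compounds shown leave open whether 3,5-dimethylphenyl in place of 2-bromophenyl changes the tolerated concentration at all, and in which direction.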